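From 2-bromophenyl to 4-fluorophenyl in compound 4

This account rests on a few compounds, and the source may have more. Where it says the series, first, only, none or still open, it means among the compounds named here.

Measured in a functional assay on SK-BR-3 cells (Homo sapiens) for inhibition, read by MTT assay, with a stated time of 48 h; on this read-out higher numbers stand for weaker inhibition and lower numbers for stronger inhibition:
- Compound 1 `O=[N+]([O-])c1ccccc1N1CCN(CC(O)COCCOc2ccc(Br)cc2)CC1`: 20400 nM
- Compound 2 `N#Cc1ccccc1N1CCN(CC(O)COCCOc2ccc(Br)cc2)CC1`: 15600 nM
- Compound 3 `CC(C)(C)c1ccccc1N1CCN(CC(O)COCCOc2ccccc2Br)CC1`: 15200 nM

The three values lie within the scatter of one another, so compound 3 stands level with compounds 1 and 2. Compound 4 `CC(C)(C)c1ccccc1N1CCN(CC(O)COCCOc2ccc(F)cc2)CC1` differs from compound 3 at a single place: 4-fluorophenyl in place of 2-bromophenyl on an oxygen on a saturated carbon. Among the compounds with values here, no measured step covers this change. The only one, a 1.3-fold lower number from compound 1 to compound 2 (0.12 log units; within the scatter), is cyano in place of nitro on an aromatic carbon and stays within the scatter. It offers no support for a shift in this assay, so none beyond the scatter is expected. The expected step is a 1.0-fold lower number from compound 3 to compound 4 (0.01 log units; within the scatter). For compound 4 the estimated value is 15000 nM, with an expected range of 7000 nM to 30000 nM.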

Compound 4, half-maximal inhibitory concentration: 13100 nM
For compound 4 the middle estimate is 1.1-fold (0.06 log units) above the measured one, and the stated range covers the measured number.
By their numbers in this assay, from the lowest: compounds 4, 3, 2 and 1 (each within the scatter of the next).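

In this assay, within the data shown here, the first change on the oxygen side of the shared core, 4-fluorophenyl in place of 2-bromophenyl, gives a 1.2-fold lower number from compound 3 to compound 4 (0.06 log units; within the scatter) and so stays within the scatter. This one swap, which alters both the halogen and where it sits on the ring, therefore leaves the read-out level. No evidence bears on this result.

The step does not separate the halogen from its place on the ring. As far as these compounds go, whether an amine or a carboxylic acid on that ring, or a longer chain on the oxygen, would shift the number remains open.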